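Extending an alkoxy chain on a brominated bis-benzylidene cyclohexanone

The source may report more compounds than this note shows. Statements on the series, on what has been measured and on what is new or still open speak of the compounds shown alone.

Three bis-benzylidene cyclohexanones carrying a bromine and a nitrophenyl group have been tested in a functional assay on MDA-MB-231 cells (Homo sapiens) for cytotoxicity, read by MTT assay; on this read-out lower numbers stand for stronger inhibition and higher numbers for weaker inhibition. Compound 1 `COc1cc(/C=C2\CCC/C(=C\c3cccc([N+](=O)[O-])c3)C2=O)cc(Br)c1OC` gives 13.9 ug/mL. Compound 2 `CCOc1c(Br)cc(/C=C2\CCC/C(=C\c3cccc([N+](=O)[O-])c3)C2=O)cc1OC` gives 19.3 ug/mL, and the change methyl in place of hydrogen on a saturated chain carbon bound to an oxygen on an aromatic ring made a step of a 1.4-fold higher number from compound 1 to compound 2 (0.14 log units; within the scatter). Compound 3 `CCOc1c(Br)cc(/C=C2\CCC/C(=C\c3ccc([N+](=O)[O-])cc3)C2=O)cc1OC` gives 34.7 ug/mL, with a step of a 1.8-fold higher number from compound 2 to compound 3 (0.25 log units; within the scatter) from its neighbour; how the cores of compound 1 and compound 3 differ is not broken down here.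

Compound 4 `CCCOc1c(Br)cc(/C=C2\CCC/C(=C\c3ccc([N+](=O)[O-])cc3)C2=O)cc1OC` is not yet measured. It arises from compound 3 by the change (methyl in place of hydrogen on a saturated chain carbon, two bonds along the chain from an oxygen on an aromatic ring), the same kind of change as from compound 1 to compound 2, though there the methyl entered on a saturated chain carbon bound to an oxygen on an aromatic ring, whereas here it enters two bonds along the chain from that oxygen. Because the earlier step was a 1.4-fold higher number from compound 1 to compound 2 (0.14 log units; within the scatter), a similarly small step of a 1.2-fold higher number from compound 3 to compound 4 (0.08 log units; within the scatter) is expected. Compound 4 is therefore estimated to give 42 ug/mL in this assay, most likely between 20 ug/mL and 85 ug/mL.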

Compound 4, half-maximal inhibitory concentration: 4.01 ug/mL
Compound 4: the middle estimate sits 10-fold (1.02 log units) above what was measured, outside the stated range (below it).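

In this assay, going from ethoxy to propoxy gave an 8.7-fold lower number from compound 3 to compound 4 (0.94 log units; beyond the scatter), and the earlier step on the other core does not predict it: the same change on two cores in this assay, a 1.4-fold higher number (0.14 log units; within the scatter) from compound 1 to compound 2 and an 8.7-fold lower number (0.94 log units; beyond the scatter) from compound 3 to compound 4, 12-fold (1.08 log units) apart, beyond the scatter of two such steps. The two steps also differ in where the methyl enters, on a saturated chain carbon bound to an oxygen on an aromatic ring in one and two bonds along the chain in the other, so the gap cannot be assigned to the core or the place alone. Each step rests on a single pair of compounds, and the data do not show why the two differ.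

Going by these compounds, it remains open whether propoxy gives a similar step on the core of compound 2. A longer chain, such as butoxy, on the core of compound 4 is also untested among the compounds shown.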